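The compounds below may be only part of what the source reports. "The series", "measured", "known", "first", "only" and "open" are said of these compounds alone.

Measured so far in an ADME assay on the whole organism (Mus musculus) for metabolic stability, using cassette dosing, at a dose of 1 umol/kg by the intravenous route; a higher number here means that the compound lasts longer, a lower number that the compound disappears faster:
- compound 1, `Cc1ccc(C(=O)Nc2cn3ncnc3c(O[C@H]3CCN(C(=O)CC(C(F)(F)F)C(F)(F)F)[C@@H](C)C3)c2C)cn1`: 3.9 h
- compound 2, `Cc1ccc(C(=O)Nc2cn3ncnc3c(CN3CCN(C(=O)C4CCCC4)[C@@H](C)C3)c2C)cn1`: 1.4 h
- compound 3, `Cc1ccc(C(=O)Nc2cc(F)cc(CN3CCN(C(=O)C4CCCC4)[C@@H](C)C3)c2C)cn1`: 0.7 h

Compound 2 sits second highest of the three numbers. Its nearest neighbour is compound 3, whose gap from compound 2 lies within the usual scatter, so the two cannot be told apart on these data. Its furthest neighbour is compound 1, whose gap from compound 2 lies beyond the scatter, so compound 1 lasts longer than compound 2 in this assay.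

The next compound, compound 4, `Cc1ccc(C(=O)Nc2cn3ncnc3c(CN3CCN(C(=O)CC(C(F)(F)F)C(F)(F)F)[C@@H](C)C3)c2C)cn1`, is not yet measured. It differs from compound 2 in one place: 3,3,3-trifluoro-2-(trifluoromethyl)propyl in place of cyclopentyl on a carbonyl carbon. The group that enters is the same one that compound 1 carries on its own carbonyl, and compound 1 gives 3.9 h, whereas the shared core of compound 2 and compound 4 is otherwise unchanged. Among the measured compounds shown here, no step between measured compounds isolates this exchange, so the expectation rests on that comparison alone.

An upward step from compound 2 to compound 4 of a 1.9-fold higher number from compound 2 to compound 4 (0.27 log units; within the scatter) is expected, beyond the scatter but not reaching the value of compound 1. Compound 4 is estimated at 2.6 h, with a range from 1.2 h to 5.5 h.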

Compound 4, half-life: 1 h
Estimate against measurement, compound 4: 2.6-fold (0.41 log units) above, outside the stated range (below it).
By their numbers in this assay, from the lowest: compounds 3, 4 and 2 (each within the scatter of the next); then compound 1.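

In this assay the exchange of cyclopentyl for 3,3,3-trifluoro-2-(trifluoromethyl)propyl on a carbonyl carbon gives a 1.4-fold lower number from compound 2 to compound 4 (0.15 log units; within the scatter) and leaves compound 2 and compound 4 indistinguishable, so on this core the much larger fluorinated group brings no readable change in half-life. Carrying this group therefore does not by itself give a number like that of compound 1 at 3.9 h in this assay and the parts of compound 1 that differ from compound 4 remain unresolved as a source of that number. No measurement shown here explains the flat result.

Still open, going by these compounds, is whether cyclopentyl on the core of compound 1 would give a half-life close to that of compound 1 or a clearly lower one, which would show how far the acyl group matters on that core. Also open, on these data alone, is whether a different group on this carbonyl, such as a phenyl ring, a longer straight alkyl chain or a carboxylic acid, would move the half-life beyond the scatter from compound 2.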